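Three Limits and an Unmeasured Trifluoromethoxy Analogue

The source may hold more compounds than are shown below. What is called first, only, known or untested is meant among the compounds shown, and "the series" means these compounds.

Compound 1 `COc1cccc(S(=O)(=O)NC2=NCCN2C(=S)SN2CCn3c2nsc3=S)c1`, compound 2 `COc1ccc(S(=O)(=O)NC2=NCCN2C(=S)SN2CCn3c2nsc3=S)cc1` and compound 3 `O=S(=O)(NC1=NCCN1C(=S)SN1CCn2c1nsc2=S)c1cccc(OC(F)(F)F)c1` were tested in a functional assay on KYSE-510 cells (Homo sapiens) for antiproliferative activity, read by crystal violet staining, with a stated time of 96 h; a lower number here means a stronger inhibitor of growth, a higher number a weaker inhibitor of growth. Compound 1 gives only a limit, >= 20000 nM. Compound 2 likewise gives only a limit, >= 20000 nM. Compound 3 also gives only a limit, >= 20000 nM. Compound 2 differs from compound 1 by 4-methoxyphenyl in place of 3-methoxyphenyl on a sulfonyl sulfur, and the step is a step that the two limits leave unreadable from compound 1 to compound 2. Compound 3 differs from compound 1 by trifluoromethyl in place of methyl on an oxygen on an aromatic ring, and that step is a step that the two limits leave unreadable from compound 1 to compound 3. Compound 4 `O=S(=O)(NC1=NCCN1C(=S)SN1CCn2c1nsc2=S)c1ccc(OC(F)(F)F)cc1`, not yet measured, differs from compound 2 by trifluoromethyl in place of methyl on an oxygen on an aromatic ring, the same change at the same place as from compound 1 to compound 3. Because all three measured values sit at the limit of >= 20000 nM in this assay, at which 3 of the 3 values shown sit, compound 4 is expected to remain at that limit. The expected step is a step that the limit leaves unreadable from compound 2 to compound 4. For compound 4 the estimate is 30000 nM, expected to lie between 15000 nM and 100000 nM.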

Compound 4, concentration for 50% growth inhibition: >= 20000 nM
Compound 4: no number, only a limit; the forecaster's own chance of this, stated with the estimate: 85%; the middle value is on the limit's open side.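

Compound 2 and compound 4 both stand only as limits, so no new step can be read between them. The compounds shown leave open what number lies behind each limit, and whether methoxy to trifluoromethoxy alters growth inhibition at all.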